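Nitro on the lactam benzyl: expected effect in compound 4

The compounds below may be only part of what the source reports. "The series", "measured", "known", "first", "only" and "open" are said of these compounds alone.

Compound 1 `N=C(NCc1ccccc1)[C@@H]1CCC(=O)N1Cc1ccccc1` is the reference of this small set. In a functional assay on SH-SY5Y cells (Homo sapiens) for cytotoxicity, read by MTT assay, with stated times of 8 h, 30 min and 12 h, tested at 0.5 uM (a lower number here means a weaker effect, a higher number a stronger effect of the compound at the concentration tested), compound 1 gives 27.9%. Compound 2 `N=C(NCc1ccc(O)cc1)[C@@H]1CCC(=O)N1Cc1ccccc1` differs from it by hydrogen in place of hydroxy on an aromatic carbon; in this assay compound 2 gives 35.4%, and the step of a number 7.5 percentage points higher from compound 1 to compound 2 (within the scatter) stays within the scatter. Compound 3 `N=C(NCc1ccc(O)cc1)[C@@H]1CCC(=O)N1Cc1ccccc1[N+](=O)[O-]` carries the change nitro in place of hydrogen on an aromatic carbon on the core of compound 2; in this assay compound 3 gives 26.9%, so the step of a number 8.5 percentage points lower from compound 2 to compound 3 (within the scatter) is also within the scatter. Compound 4 `N=C(NCc1ccccc1)[C@@H]1CCC(=O)N1Cc1ccc([N+](=O)[O-])cc1` is not yet measured and carries the change nitro in place of hydrogen on an aromatic carbon on the core of compound 1. Around the place the two changes are not the same: in compound 3 the nitro sits ortho to a large group, in compound 4 para to a large group, so this is the same kind of change, not the same. Going by the values given here, because the only measured nitro step, a number 8.5 percentage points lower from compound 2 to compound 3 (within the scatter), lies within the scatter, the step of a number 2.9 percentage points lower from compound 1 to compound 4 (within the scatter) is expected to be small as well. Compound 4 is therefore estimated at 25%, with a plausible range from 14% to 37%.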

Compound 4, a percentage reported as activity, at one concentration (the size of the read-out at that concentration, not a potency): 24%
Estimate against measurement, compound 4: 1 percentage points above, within the range that was stated.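

In this assay nitro in place of hydrogen on an aromatic carbon, para to a large group, gives a number 3.9 percentage points lower from compound 1 to compound 4 (within the scatter) and so has no readable effect on the core of compound 1. Set beside the earlier nitro step, the change carries between the two cores without a detectable difference: the same change on two cores in this assay, a number 8.5 percentage points lower (within the scatter) from compound 2 to compound 3 and a number 3.9 percentage points lower (within the scatter) from compound 1 to compound 4, 4.6 percentage points apart, within the scatter of two such steps

This agreement rests on two small steps, each inside the scatter, so it shows no shared nitro effect that could be expected on a further core, and it cannot separate the placement of the nitro group from the presence of the hydroxy group in compound 3. As far as these compounds go, whether an amine or a carboxylic acid at the same place would move the read-out beyond the scatter remains open. Also open are the effect of a longer chain in place of either benzyl group and the behaviour of these compounds at other concentrations.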